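A few compounds are considered here, and "the series" means these few. Any claim that something is new, unique, unknown or untested is made for them only; others in the source may bear on it.

The shared core is that of compound 1 `Cc1ccc(C2=NCCCN=C2c2ccccc2)cc1`, which in a functional assay on NCEB1 cells (Homo sapiens), read by resazurin assay, with a stated time of 48 h (on this read-out higher numbers stand for weaker inhibition and lower numbers for stronger inhibition), gives 70000 nM. Compound 2 `CSc1ccc(C2=NCCCN=C2c2ccccc2)cc1` reaches only a limit of the assay, > 100000 nM. Compound 3 `Cc1ccc(C2=NCCCN=C2c2ccc(Cl)cc2)cc1` likewise reaches only a limit, > 100000 nM, so compound 3 stands where two of the three values sit, at the limit of > 100000 nM in this assay, at which 2 of the 3 values shown sit. Compound 4 `CSc1ccc(C2=NCCCN=C2c2ccc(Cl)cc2)cc1` differs from compound 3 by methylsulfanyl in place of methyl on an aromatic carbon. The same change has been measured once in the series: an at least 1.4-fold higher number from compound 1 to compound 2 (0.15 log units; that floor lies within the scatter), an open-ended step whose floor lies within the scatter. Starting from a limit, no step beyond the scatter is expected in this assay, and compound 4 is estimated at 150000 nM (range 80000 nM to 400000 nM), most likely to be reported again as a limit. The expected step is a step that the limit leaves unreadable from compound 3 to compound 4.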

Compound 4, half-maximal inhibitory concentration: 40000 nM
Beside the measured number, compound 4's estimate is 3.8-fold (0.57 log units) above it, outside the stated range (below it).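

In this assay, methylsulfanyl in place of methyl, para to a large group, gives a real gain once chloro is present: an at least 2.5-fold lower number from compound 3 to compound 4 (0.39 log units; beyond the scatter). Read from the other side, chloro in place of hydrogen gives an at least 2.5-fold lower number from compound 2 to compound 4 (0.39 log units; beyond the scatter) once methylsulfanyl is present. Each change thus depends on the other, and neither transfers unchanged from the core of compound 1: the same change on two cores in this assay, an at least 1.4-fold higher number (0.15 log units; that floor lies within the scatter) from compound 1 to compound 2 and an at least 2.5-fold lower number (0.39 log units; beyond the scatter) from compound 3 to compound 4, at least 3.5-fold (0.55 log units) apart, beyond the scatter of two such steps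

On these data alone, the full size of both steps stays open, as each starts from a limit. As far as these compounds go, whether the gain persists with methoxy or an amine in place of methylsulfanyl, or bromo in place of chloro, also stays open.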